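The source may hold more compounds than are shown below. What is called first, only, known or untested is meant among the compounds shown, and "the series" means these compounds.

Of the compounds shown here, three sharing one core have been tested in an assay on HEK293 cells for inhibition of Steryl-sulfatase (Homo sapiens), tested at 0.1 uM; a lower number here means a weaker effect, a higher number a stronger effect of the compound at the concentration tested. Compound 1 `CCCN(CCC)c1ccc(C(=O)N2CCc3ccc(OS(N)(=O)=O)cc3C2)cc1` gives 36.6% there, compound 2 `CCN(Cc1ccc(Br)cc1)c1ccc(C(=O)N2CCc3ccc(OS(N)(=O)=O)cc3C2)cc1` gives 78.2%, and compound 3 `CC(C)CCN(CCC(C)C)c1cccc(C(=O)N2CCc3ccc(OS(N)(=O)=O)cc3C2)c1` gives 32.3%. Compound 3 thus has the lowest of the three numbers, although its gap to compound 1 lies within the scatter, while compound 2 stands well beyond both.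

Compound 4 `CCN(Cc1cccnc1)c1cccc(C(=O)N2CCc3ccc(OS(N)(=O)=O)cc3C2)c1` has not yet been measured. It differs from compound 3 in one place: ethyl((pyridin-3-yl)methyl)amino in place of diisopentylamino on an aromatic carbon.

Within the data shown here, the only measured step that bears on this change is the one in which a dialkylamino group gave way to an ethyl(arylmethyl)amino group, a number 41.6 percentage points higher from compound 1 to compound 2 (beyond the scatter). The present change is of the same kind, though on a different aromatic position and with a pyridinylmethyl rather than a bromobenzyl group, so the size of the step is less certain. Compound 4 is therefore expected to show a rise, a number 22.7 percentage points higher from compound 3 to compound 4 (beyond the scatter), and its estimated value in this assay is 55%, with a range from 30% to 80%.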

Compound 4, a percentage reported as inhibition, at one concentration (the size of the read-out at that concentration, not a potency): 14.3%
Compound 4: middle estimate off by 40.7 percentage points, on the high side; the measured number lies below the stated range.
By their numbers in this assay, from the lowest: compound 4; then compounds 3 and 1 (each within the scatter of the next); then compound 2.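

On an aromatic carbon meta to a large group, the change to ethyl((pyridin-3-yl)methyl)amino brings no gain in this assay and instead gives a number 18 percentage points lower from compound 3 to compound 4 (beyond the scatter) as its result. The rise of a number 41.6 percentage points higher from compound 1 to compound 2 (beyond the scatter) seen with (4-bromobenzyl)(ethyl)amino therefore does not carry over to this change, so an ethylamino group bearing an aromatic ring does not raise the number in every setting. No measurement shown here explains the opposite directions of these two steps.

The two steps differ both in the ring carried and in where the group sits, so the compounds shown cannot separate these two factors. Going by these compounds, it also remains open what benzyl(ethyl)amino, with neither a bromine nor a ring nitrogen, or (4-bromobenzyl)(ethyl)amino would give in the place held by the group of compound 4.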